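The source may hold more compounds than are shown below. What is called first, only, known or untested is meant among the compounds shown, and "the series" means these compounds.

Compound 1 `Nc1cccc(-c2cccc(NC(=O)C(Cl)Cl)c2)c1`: in a functional assay on NCI-H460 cells (Homo sapiens) for cytotoxicity, read by MTT assay, with a stated time of 68 h (a higher number here means a weaker inhibitor, a lower number a stronger inhibitor), compound 1 gives > 50000 nM, which is a limit of the assay and not a number.
Compound 2 `O=C(Nc1cccc(-c2ccccc2F)c1)C(Cl)Cl`: in this assay compound 2 gives 26800 nM.
Compound 3 `O=C(Nc1cccc(-c2ccc(F)cc2)c1)C(Cl)Cl`: in this assay compound 3 gives > 50000 nM, again a limit of the assay.

Compound 1 thus stands at the limit of > 50000 nM in this assay, at which 2 of the 3 values shown sit, so it cannot be ranked against the other two. Compound 4 `O=C(Nc1cccc(-c2ccccc2)c1)C(Cl)Cl`, not yet measured, differs from compound 1 in one place: hydrogen in place of amino on an aromatic carbon. Going by the values given here, no measured pair shows this change, and compound 2 and compound 3 carry a different change on the shared core. In this assay the step is expected to be small, not beyond the scatter, an at least 1.2-fold lower number from compound 1 to compound 4 (0.09 log units; that floor lies within the scatter). Compound 4 is expected to give 40000 nM, between 15000 nM and 50000 nM, with a real chance that only a limit is reported.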

Compound 4, half-maximal inhibitory concentration: 20200 nM
Compound 4: the middle estimate sits 2.0-fold (0.30 log units) above what was measured; measured number inside the range.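

Hydrogen in place of amino on the aromatic carbon gives an at least 2.4-fold lower number from compound 1 to compound 4 (0.39 log units; beyond the scatter), the first sign that this position can move the number. Hydrogen in place of fluoro depends on where the fluoro sits, with an at least 2.4-fold lower number from compound 3 to compound 4 (0.39 log units; beyond the scatter) but only a 1.3-fold lower number from compound 2 to compound 4 (0.12 log units; within the scatter). Compound 1 and compound 3 each stand at a limit, so the full size of their steps stays unknown: the limit of > 50000 nM in this assay, at which 2 of the 4 values shown sit.

The compounds shown leave open whether a methoxy group or a carboxylic acid on that aromatic carbon would lower the number further or raise it, as amino does.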